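Aryl swap on a shared amide core: cytotoxicity notes

This account rests on a few compounds, and the source may have more. Where it says the series, first, only, none or still open, it means among the compounds named here.

Compound 1 `COc1cc2c(Oc3ccc(NC(=O)c4cc(-c5cccc(Cl)c5)nc5ccccc45)cc3F)ccnc2cc1OCCCN1CCC(C)CC1` gives 30 nM in a functional assay on MKN-45 cells (Homo sapiens) for cytotoxicity, read by MTT assay, with a stated time of 72 h; a lower number here means a stronger inhibitor, a higher number a weaker inhibitor. Among the compounds with values here, compound 2 `COc1ccc(-c2cc(C(=O)Nc3ccc(Oc4ccnc5cc(OCCCN6CCC(C)CC6)c(OC)cc45)c(F)c3)c3ccccc3n2)cc1` carries 4-methoxyphenyl in place of 3-chlorophenyl on an aromatic carbon and gives 320 nM; the step of an 11-fold higher number from compound 1 to compound 2 (1.03 log units; beyond the scatter) is the only counted change in this set. Compound 3 `COc1cc2c(Oc3ccc(NC(=O)c4cc(-c5cccc(Cl)c5)nc5ccc(F)cc45)cc3F)ccnc2cc1OCCCN1CCCC1` gives 67 nM; how its core differs from the core of compound 1 is not broken down here. Compound 4 `COc1ccc(-c2cc(C(=O)Nc3ccc(Oc4ccnc5cc(OCCCN6CCCC6)c(OC)cc45)c(F)c3)c3cc(F)ccc3n2)cc1` is not yet measured and differs from compound 3 by 4-methoxyphenyl in place of 3-chlorophenyl on an aromatic carbon, the same change as that from compound 1 to compound 2, at a place described in the same words. Within the data shown here, the step from compound 3 to compound 4 is expected to be about a 9.7-fold higher number from compound 3 to compound 4 (0.99 log units; beyond the scatter), beside the earlier one, because an 11-fold higher number from compound 1 to compound 2 (1.03 log units; beyond the scatter) is the sole guide and the change is the same. Compound 4 is therefore estimated at 650 nM, with a range from 250 nM to 1800 nM allowing for the different core.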

Compound 4, half-maximal inhibitory concentration: 170 nM
For compound 4 the middle estimate is 3.8-fold (0.58 log units) above the measured one; measured number outside the range, below it.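

In this assay the swap of 3-chlorophenyl for 4-methoxyphenyl again raises the number, with a 2.5-fold higher number from compound 3 to compound 4 (0.40 log units; beyond the scatter) on the core of compound 3, so the direction holds on both cores shown. The size of the step does not carry over from one core to the other: the same change on two cores in this assay, an 11-fold higher number (1.03 log units; beyond the scatter) from compound 1 to compound 2 and a 2.5-fold higher number (0.40 log units; beyond the scatter) from compound 3 to compound 4, 4.2-fold (0.62 log units) apart, beyond the scatter of two such steps

Which part of the core difference goes with the smaller step is not shown, and two pairs give no rule for predicting the step on a further core. Still open, on these data alone, is whether 4-chlorophenyl or 3-methoxyphenyl would separate the effect of the substituent from that of its ring position. Also open, as far as these compounds go, is how large the step would be on a core carrying a morpholine.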